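The compounds below may be only part of what the source reports. "The series", "measured", "known", "first", "only" and "open" are said of these compounds alone.

Measured compounds:
- compound 1, `CC(C(=O)NCc1ccc(C(F)(F)F)nc1N1CCC(Cc2ccc(F)c(F)c2)CC1)c1ccc(NS(C)(=O)=O)c(F)c1`, in a functional assay on CHO-K1 cells for antagonist activity at transient receptor potential cation channel subfamily V member 1 (Homo sapiens), read by FLIPR (on this read-out lower numbers stand for stronger inhibition and higher numbers for weaker inhibition), gives 30 nM
- compound 2, `CC(C(=O)NCc1ccc(C(F)(F)F)nc1N1CCC(C(F)(F)F)CC1)c1ccc(NS(C)(=O)=O)c(F)c1`, in this assay gives 31 nM
- compound 3, `COC1CCN(c2nc(C(F)(F)F)ccc2CNC(=O)C(C)c2ccc(NS(C)(=O)=O)c(F)c2)CC1`, in this assay gives 280 nM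

Compound 3 stands at the highest number of the three. The steps of a 9.3-fold higher number from compound 1 to compound 3 (0.97 log units; beyond the scatter) and a 9.0-fold higher number from compound 2 to compound 3 (0.96 log units; beyond the scatter) both lie beyond the scatter, while a 1.0-fold higher number from compound 1 to compound 2 (0.01 log units; within the scatter) lies within it, so the two substituents other than methoxy on the saturated ring carbon cannot be told apart on these numbers, and methoxy is the one that gives the weaker read-out.

Compound 4, `CC(C(=O)NCc1ccc(C(F)(F)F)nc1N1CCC(OC(=O)C(C)(C)C)CC1)c1ccc(NS(C)(=O)=O)c(F)c1`, is not yet measured. It differs from compound 3 in one place: (tert-butyl)carbonyl in place of methyl on an oxygen on a saturated carbon. Going by the values given here, no measured step covers this entering group, so the nearest guide is that both recorded exchanges of methoxy for another group at this position, a 9.3-fold higher number from compound 1 to compound 3 (0.97 log units; beyond the scatter) read in reverse and a 9.0-fold higher number from compound 2 to compound 3 (0.96 log units; beyond the scatter) read in reverse, moved the number down by a modest amount. On that basis a lower number than compound 3 is expected for compound 4, though with wide uncertainty, as a step of a 3.1-fold lower number from compound 3 to compound 4 (0.49 log units; beyond the scatter) is only an expectation drawn from two exchanges of a different kind. Compound 4 is estimated at 90 nM in this assay, with a range from 25 nM to 350 nM.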

Compound 4, half-maximal inhibitory concentration: 45.2 nM
Beside the measured number, compound 4's estimate is 2.0-fold (0.30 log units) above it; measured number inside the range.
By their numbers in this assay, from the lowest: compounds 1, 2 and 4 (each within the scatter of the next); then compound 3.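

In this assay, an oxygen on the saturated ring carbon is not enough on its own to give the higher number: with (tert-butyl)carbonyl in place of methyl on that same oxygen, the read-out moves well beyond the scatter (a 6.2-fold lower number from compound 3 to compound 4 (0.79 log units; beyond the scatter)). The earlier compounds could only set methoxy against two substituents without oxygen, whereas ((tert-butyl)carbonyl)oxy now stands level with trifluoromethyl (a 1.5-fold higher number from compound 2 to compound 4 (0.16 log units; within the scatter)) and 3,4-difluorobenzyl (a 1.5-fold higher number from compound 1 to compound 4 (0.18 log units; within the scatter)), both steps within the scatter; three differently built substituents cannot be told apart here, and among these four compounds methoxy alone stands apart. Nothing measured on these compounds offers an explanation for this, and the finding remains a description of the numbers.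

What the compounds leave open is which part of the ester goes with the lower number: a free hydroxyl, an acetyl ester or a pivalamide at this carbon would separate the carbonyl from the tert-butyl part. Going by these compounds, whether methoxy is an isolated case also stays open, and an ethoxy or a benzyloxy group on the same oxygen would test how far the higher number extends among simple ethers.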